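The source may report more compounds than this note shows. Statements on the series, on what has been measured and on what is new or still open speak of the compounds shown alone.

Measured so far in an in vitro ADME assay on microsomes from liver (Homo sapiens) for metabolic stability, read by LC-MS; a lower number here means that the compound disappears faster, a higher number that the compound lasts longer:
compound 1, `Cc1ccc(NC(=O)N2CCCN(C(=O)CCC3CCCC3)CC2)cc1`, 0.0667 h
compound 2, `CC(C)(C)c1ccc(NC(=O)N2CCCN(C(=O)CCC3CCCC3)CC2)cc1`, 0.05 h

Going by the values given here, compound 2 sits at the lower of the two numbers in this assay, but the only measured step, a 1.3-fold lower number from compound 1 to compound 2 (0.13 log units; within the scatter), lies within the scatter, so compound 1 and compound 2 cannot be told apart on their half-lives. Both disappear quickly.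

Compound 3, `CC(C)(C)c1ccc(NC(=O)N2CCCN(C(=O)CC3CCCC3)CC2)cc1`, has not yet been measured in this assay. It differs from compound 2 in one place: cyclopentyl in place of cyclopentylmethyl on a saturated chain carbon bound to a carbonyl carbon. In other words, the chain between the carbonyl and the five-membered ring is shortened by one carbon on the acyl side, while the aryl end of the shared core stays unchanged.

Among the compounds with values here, no measured step touches this part of the molecule. Within the data shown here, the one step known, from the aryl side, was within the scatter and says nothing about the acyl chain. With nothing to lean on, the expectation for compound 3 is a step of about a 1.2-fold higher number from compound 2 to compound 3 (0.08 log units; within the scatter), that is, no change beyond the scatter.

Compound 3 is therefore estimated at 0.06 h, within a range from 0.025 h to 0.15 h.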

Compound 3, half-life: 0.05 h
The estimate for compound 3 lay 1.2-fold (0.08 log units) above the measured number; the measured number falls inside the stated range.
By their numbers in this assay, from the lowest: compounds 2, 3 and 1 (each within the scatter of the next).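

In this assay, going by these compounds alone, the only measured step at this acyl position, on a saturated chain carbon bound to a carbonyl carbon, is no change at the digits printed from compound 2 to compound 3 (within the scatter). Putting cyclopentyl in place of cyclopentylmethyl takes the group from 6 heavy atoms to 5 and keeps its five-membered ring of carbon only, yet the two half-lives cannot be told apart. Among the compounds shown, then, neither this change nor the earlier swap of methyl for tert-butyl on the aromatic ring separates one half-life from another, and no measurement at hand offers an explanation for the result at this position.

As far as these compounds go, only these two all-carbon groups are compared here, so it remains open whether a longer chain, or a group that brings in other atoms, such as an amine or a carboxylic acid, would shift the half-life beyond the scatter. The pair also carries tert-butyl on the aromatic ring, which leaves open whether the same swap would read the same with the methyl group of compound 1.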